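The source may report more compounds than this note shows. Statements on the series, on what has been measured and on what is new or still open speak of the compounds shown alone.

compound 1 `Cc1ccccc1-c1nn(-c2cc(F)ccc2F)cc1CNCCN1CCN(C)CC1`: > 20000 nM
compound 2 `Cc1ccccc1-c1nn(-c2ccc(F)cc2F)cc1CNCc1ccncc1`: > 20000 nM

In an ADME assay on Huh-7 cells (Homo sapiens) for cytotoxicity (a higher number here means that more compound is tolerated, a lower number that less compound is tolerated), compound 1 gives > 20000 nM, which is a limit of the assay rather than a measured number. Compound 2 gives > 20000 nM in this assay, also a limit. Both values therefore stand at the limit of > 20000 nM in this assay, at which 2 of the 2 values shown sit, so nothing separates them. Compound 3 `Cc1ccccc1-c1nn(-c2ccc(N)cc2)cc1CNCCN1CCN(C)CC1` differs from compound 1 by 4-aminophenyl in place of 2,5-difluorophenyl on an aromatic nitrogen. Going by the values given here, no measured step of this kind exists for comparison, and with both measured compounds at the limit, no step beyond the usual scatter is expected in this assay in either direction. Compound 3 is estimated at 20000 nM (range 8000 nM to 50000 nM), an expected step of a number no higher from compound 1 to compound 3 (the limit leaves the size open).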

Compound 3, half-maximal cytotoxic concentration: > 20000 nM
Compound 3 gave a limit, no number (the forecaster's own chance of this, stated with the estimate: 80%); the middle value sits exactly at the limit.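

In this assay compound 3 gives > 20000 nM, again a limit of the assay, so the change from compound 1 to compound 3 cannot be read: the limit of > 20000 nM in this assay, at which 3 of the 3 values shown sit.

The compounds shown leave open whether 4-aminophenyl in place of 2,5-difluorophenyl changes the result in this assay in either direction.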